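Amino chalcone series: adding a methoxy to compound 2

The source may hold more compounds than are shown below. What is called first, only, known or untested is meant among the compounds shown, and "the series" means these compounds.

Measured so far in a functional assay on L1210 cells (Mus musculus) for antiproliferative activity, with a stated time of 48 h; a higher number here means a weaker inhibitor, a lower number a stronger inhibitor:
compound 1 `C=C(Br)C(=O)Nc1ccc(/C=C/C(=O)c2cccc(OC)c2)cc1` gives 2100 nM
compound 2 `Nc1ccc(/C=C/C(=O)c2ccccc2)cc1` gives 88000 nM

Compound 2 has the higher number of the two, which makes it the weaker inhibitor, and its gap to compound 1 lies beyond the scatter. The two compounds differ in more than one place, so that gap belongs to no single change. Among the measured compounds shown here, compound 3 `COc1cccc(C(=O)/C=C/c2ccc(N)cc2)c1` is compound 2 with methoxy in place of hydrogen on an aromatic carbon as its only change, methoxy in place of hydrogen on an aromatic carbon, meta to a large group. For the measured compounds named here, compound 1 also carries a methoxy, but no measured pair isolates that group. A modest move towards a lower number is expected in this assay and it may stay close to the scatter. The estimated size of the move is a 2.2-fold lower number from compound 2 to compound 3 (0.34 log units; beyond the scatter) for this single change. For compound 3 the expected value is 40000 nM with an estimated range of 13000 nM to 100000 nM for now.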

Compound 3, half-maximal inhibitory concentration: 38000 nM
The estimate for compound 3 lay 1.1-fold (0.02 log units) above the measured number; the measured number falls inside the stated range.
By their numbers in this assay, from the lowest: compound 1; then compound 3; then compound 2.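

In this assay, methoxy in place of hydrogen on an aromatic carbon, meta to a large group, gives a 2.3-fold lower number from compound 2 to compound 3 (0.36 log units; beyond the scatter), so this position accepts the group with a modest gain on the amino compound. Compound 3 also provides the first single-change link to compound 1: hydrogen in place of (1-bromoethenyl)carbonyl on the nitrogen gives an 18-fold higher number from compound 1 to compound 3 (1.26 log units; beyond the scatter), a large step that far exceeds the methoxy step. No measurement available here accounts for either step.

Open, as far as these compounds go, is whether the gain belongs to methoxy itself or would also appear with a hydroxyl or a fluorine at this place. Also open, from the compounds shown here alone, is whether an acetyl on the same nitrogen would retain any of the gain seen with (1-bromoethenyl)carbonyl.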